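The source may report more compounds than this note shows. Statements on the series, on what has been measured and on what is new or still open speak of the compounds shown alone.

Compound 1 `CC(C(=O)NCc1ccc(C(F)(F)F)nc1N1CCCC1)c1ccc(NS(C)(=O)=O)c(F)c1` is the reference point of the series. In a functional assay on CHO-K1 cells for antagonist activity at transient receptor potential cation channel subfamily V member 1 (Homo sapiens), read by FLIPR (on this read-out higher numbers stand for weaker inhibition and lower numbers for stronger inhibition), compound 1 gives 0.6 nM. Going by the values given here, the only other measured compound, compound 2 `C[C@H](C(=O)NCc1ccc(C(F)(F)F)nc1N1CCC(c2ccccc2)CC1)c1ccc(NS(C)(=O)=O)c(F)c1`, gives 0.3 nM in this assay; the two numbers lie within the usual scatter of each other, so no ordering of the two follows. Compound 3 `CC(C(=O)NCc1ccc(C(F)(F)F)nc1N1CCN(C2CCCCC2)CC1)c1ccc(NS(C)(=O)=O)c(F)c1` carries the change (4-cyclohexylpiperazin-1-yl in place of pyrrolidin-1-yl on an aromatic carbon). Among the compounds with values here, no measured pair shows a change of this kind, so nothing in the data sets the size of the step. The expected step is a 1.3-fold higher number from compound 1 to compound 3 (0.12 log units; within the scatter), small and without a clear direction beyond the scatter. Compound 3 is estimated at 0.8 nM, with a range from 0.2 nM to 3 nM.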

Compound 3, inhibition constant: 21.6 nM
Compound 3: the middle estimate sits 27-fold (1.43 log units) below what was measured; the measured number lies above the stated range.
By their numbers in this assay, from the lowest: compounds 2 and 1 (each within the scatter of the next); then compound 3.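

The position next to the ring nitrogen is not indifferent to what it carries: 4-cyclohexylpiperazin-1-yl in place of pyrrolidin-1-yl gives a 36-fold higher number from compound 1 to compound 3 (1.56 log units; beyond the scatter) in this assay. Going by these compounds alone, this is the first measured size for any single change, and it is large. No supporting data bear on why the step arises.

The compounds shown leave open whether the step follows the piperazine ring or the cyclohexyl group on it. A 4-methylpiperazin-1-yl group at this position would help to separate the two.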